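The source may report more compounds than this note shows. Statements on the series, on what has been measured and on what is new or still open speak of the compounds shown alone.

In a functional assay on SW480 cells (Homo sapiens) for antiproliferative activity, read by MTT assay, with a stated time of 48 h (a higher number here means a weaker inhibitor, a lower number a stronger inhibitor), compound 1 (`CCCCCC(CCO)n1cnc2c(Cl)ncnc21`) gives > 50000 nM, a limit and not a number. Compound 2 (`CCCCCC(CCO)n1cnc2c(NC)ncnc21`) gives > 50000 nM, also a limit. Compound 3 (`C=C(CO)C(CCCCC)n1cnc2c(Cl)ncnc21`) gives > 50000 nM, again a limit. Compound 3 therefore stands at the limit of > 50000 nM in this assay, at which 3 of the 3 values shown sit. Compound 4 (`C=C(CO)C(c1ccccc1)n1cnc2c(Cl)ncnc21`) carries phenyl in place of pentyl on a saturated chain carbon bound to an aromatic nitrogen and a double-bonded chain carbon. For the measured compounds named here, two measured steps bear on this only loosely, a step that the two limits leave unreadable from compound 1 to compound 2 and a step that the two limits leave unreadable from compound 1 to compound 3, and neither touches the pentyl group. Neither has a readable size, so the expectation is a weak one: a modest move toward a stronger inhibitor. The expected change is an at least 1.4-fold lower number from compound 3 to compound 4 (0.15 log units; that floor lies within the scatter). For compound 4 the estimated value is 35000 nM, with an expected range from 10000 nM to 80000 nM.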

Compound 4, half-maximal inhibitory concentration: 12900 nM
Beside the measured number, compound 4's estimate is 2.7-fold (0.43 log units) above it, within the range that was stated.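

In this assay, for the compounds shown here, phenyl in place of pentyl gives an at least 3.8-fold lower number from compound 3 to compound 4 (0.58 log units; beyond the scatter), the first step here with a readable size, since the earlier steps cannot be read. This shows that the group on this saturated chain carbon can change the result in this series. Compound 4 is also the only compound shown with a real number rather than a limit: the limit of > 50000 nM in this assay, at which 3 of the 4 values shown sit.

Going by these compounds, whether the aromatic ring itself matters remains open, and a cyclohexyl or benzyl group at this carbon would help to test that. On these data alone, it is also open whether methylamino in place of chloro would keep, lose or improve the result of compound 4.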